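From furan-2-yl to pyridin-2-yl on a shared core

The compounds below may be only part of what the source reports. "The series", "measured", "known", "first", "only" and "open" are said of these compounds alone.

Compound 1 `CCOC(=O)CC1C(C(=O)OCC)=C(N)Oc2ccc(-c3cc(OC)cc(OC)c3)cc21`: 10700 nM
Compound 2 `CCOC(=O)CC1C(C(=O)OCC)=C(N)Oc2ccc(-c3ccc(F)cc3)cc21`: 72100 nM
Compound 3 `CCOC(=O)CC1C(C(=O)OCC)=C(N)Oc2ccc(-c3ccco3)cc21`: > 80000 nM, a limit

All three compounds were tested in a functional assay on HL-60 cells (Homo sapiens) for cytotoxicity, read by CellTiter-Blue, with a stated time of 48 h; on this read-out lower numbers stand for stronger inhibition and higher numbers for weaker inhibition. Compound 3 gives no number there, only the limit of > 80000 nM. The next compound, compound 4 `CCOC(=O)CC1C(C(=O)OCC)=C(N)Oc2ccc(-c3ccccn3)cc21`, carries pyridin-2-yl in place of furan-2-yl on an aromatic carbon.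

Three measured steps at this same place bear on the change. Moving away from 3,5-dimethoxyphenyl raised the number both times, with a 6.7-fold higher number from compound 1 to compound 2 (0.83 log units; beyond the scatter) and an at least 7.4-fold higher number from compound 1 to compound 3 (0.87 log units; beyond the scatter). These two steps show compound 1 apart from the other two compounds. The step closest to the new change is the one between the two weaker compounds, an at least 1.1-fold higher number from compound 2 to compound 3 (0.04 log units; that floor lies within the scatter), and its floor lies within the scatter. For the measured compounds named here, no measured compound carries pyridin-2-yl, so its effect has not been observed directly. Since compound 4 also lacks 3,5-dimethoxyphenyl, it is expected to stay weak in this assay, near compound 2 at 72100 nM, with no step beyond the scatter. The expected step is an at least 1.3-fold lower number from compound 3 to compound 4 (0.12 log units; that floor lies within the scatter). For compound 4 the estimated value is 60000 nM, with an expected range of 25000 nM to 120000 nM.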

Compound 4, half-maximal inhibitory concentration: 76900 nM
The estimate for compound 4 lay 1.3-fold (0.11 log units) below the measured number; the range from low to high includes it.
By their numbers in this assay, from the lowest: compound 1; then compounds 2 and 4 (each within the scatter of the next). At a limit, above all of these: compound 3.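

In this assay, pyridin-2-yl in place of 4-fluorophenyl gives a 1.1-fold higher number from compound 2 to compound 4 (0.03 log units; within the scatter), so these two groups are not told apart at this position on the aromatic carbon of the shared core. Compound 1 stays separate from this new compound, with a 7.2-fold higher number from compound 1 to compound 4 (0.86 log units; beyond the scatter), which gives a second exact number without 3,5-dimethoxyphenyl, and that number again lies well away from compound 1. Pyridin-2-yl in place of furan-2-yl gives an at least 1.0-fold lower number from compound 3 to compound 4 (0.01 log units; that floor lies within the scatter). This step cannot be read as a size, because the value of compound 3 is a limit and not a number: the limit of > 80000 nM in this assay, at which 1 of the 4 values shown sits.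

What the compounds shown leave open is which part of 3,5-dimethoxyphenyl sets compound 1 apart, and whether a plain phenyl or a phenyl with a single methoxy group would stand with compound 1 or with compound 2 and compound 4. Also open, as far as these compounds go, is whether pyridin-3-yl, or a pyridine ring carrying two methoxy groups, would separate from pyridin-2-yl at this position in this assay.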